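The compounds below may be only part of what the source reports. "The series", "measured", "known", "first", "only" and "open" are said of these compounds alone.

Compound 1 `Oc1cc2c(cc1CNc1ccccc1)OCCC2` gives 3.5 in a physicochemical assay for lipophilicity; a lower number here means a more polar compound, a higher number a more lipophilic compound. Compound 2 `OCc1ccccc1NCc1cc2c(cc1O)CCCO2` carries hydroxymethyl in place of hydrogen on an aromatic carbon on the core of compound 1, and in this assay compound 2 gives 2.4; the step of a number 1.10 log units lower from compound 1 to compound 2 (beyond the scatter) is beyond the scatter. Compound 3 `Oc1cc2c(cc1CNc1ccccc1)OCC2` has a different core; how the cores of compound 1 and compound 3 differ is not broken down here, and in this assay compound 3 gives 2.9, which stands below compound 1 and above compound 2. Compound 4 `OCc1ccccc1NCc1cc2c(cc1O)CCO2` is made from compound 3 by hydroxymethyl in place of hydrogen on an aromatic carbon, the same change as from compound 1 to compound 2, at the same kind of place. Among the compounds with values here, the step of a number 1.10 log units lower from compound 3 to compound 4 (beyond the scatter) is expected to be about as large as the earlier one, because a number 1.10 log units lower from compound 1 to compound 2 (beyond the scatter) is the only record of this change. For compound 4 in this assay a value of 1.8 is estimated, between 1.4 and 2.2.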

Compound 4, partition coefficient: 1.9
For compound 4 the middle estimate is 0.10 log units below the measured one; the measured number falls inside the stated range.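

In this assay hydroxymethyl in place of hydrogen on an aromatic carbon gives a number 1.00 log units lower from compound 3 to compound 4 (beyond the scatter) and a number 1.10 log units lower from compound 1 to compound 2 (beyond the scatter) on the other core, so the change lowers the number by a similar amount on these two cores. This shows the step carrying over between these two cores at this one place, ortho to a large group, and does not show that it would hold on any further core or at another place. Nothing on hand bears on why the step has this size.

The compounds shown leave open whether an amine or a carboxylic acid in place of hydroxymethyl would give a comparable step on either core. Going by these compounds, a longer chain such as hydroxyethyl is equally open.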